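The compounds below may be only part of what the source reports. "The series", "measured", "known", "first", "only" and "open" are said of these compounds alone.

In a functional assay on HEY cells (Homo sapiens) for cytotoxicity, read by MTT assay, with a stated time of 72 h (on this read-out higher numbers stand for weaker inhibition and lower numbers for stronger inhibition), compound 1 (`N[C@H]1CC[C@H](Nc2c(C(=O)NCc3ccc(Oc4ccccc4)cc3)nc(Br)c3cccnc23)CC1`) gives 9000 nM and compound 2 (`CN(C)c1ccc(CNC(=O)c2nc(Br)c3cccnc3c2N[C@H]2CC[C@H](N)CC2)cc1`) gives 5300 nM, so compound 2 stands level with compound 1 within the scatter. Compound 3 (`N[C@H]1CC[C@H](Nc2c(C(=O)NCc3ccccn3)nc(Br)c3cccnc23)CC1`) keeps the shared core of compound 2 and alters the amide side: pyridin-2-yl in place of 4-(dimethylamino)phenyl on a saturated chain carbon bound to an amide-type nitrogen. Pyridin-2-yl thus takes the place of 4-(dimethylamino)phenyl on a saturated chain carbon bound to an amide-type nitrogen. For the measured compounds named here, only one measured step comes close to this change: dimethylamino in place of phenoxy on an aromatic carbon, which gave a 1.7-fold lower number from compound 1 to compound 2 (0.23 log units; within the scatter). Going by the values given here, that step does not replace the ring itself, and no measured pair does, so it offers only weak guidance. On that slim evidence, the expected step is a 1.3-fold higher number from compound 2 to compound 3 (0.12 log units; within the scatter), with no clear shift expected beyond the scatter. For compound 3 the estimated value is 7000 nM, within an expected range of 2800 nM to 18000 nM.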

Compound 3, half-maximal inhibitory concentration: > 20000 nM
Compound 3 gave a limit, no number; the forecaster's own chance of this, stated with the estimate: 15%; at least 2.8-fold (0.45 log units) between middle value and limit.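

Replacing 4-(dimethylamino)phenyl with pyridin-2-yl on a saturated chain carbon bound to an amide-type nitrogen gives an at least 3.7-fold higher number from compound 2 to compound 3 (0.57 log units; beyond the scatter), the only step shown here that lies beyond the scatter. The earlier exchange on the outer part of the aromatic ring, a 1.7-fold lower number from compound 1 to compound 2 (0.23 log units; within the scatter), left the two compounds level, so this place is not indifferent to every change: replacing the ring itself registers where that exchange did not. In this assay compound 3 gives a limit and not a number: the limit of > 20000 nM in this assay, at which 1 of the 3 values shown sits.

On these data alone, how far compound 3 really lies from compound 2 stays open, and so does whether the shift follows the ring nitrogen or the loss of the dimethylamino group. A plain phenyl ring on the same chain carbon would separate those two readings.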